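Bromo in Place of Chloro: Three Measured, One Expected

A few compounds are considered here, and "the series" means these few. Any claim that something is new, unique, unknown or untested is made for them only; others in the source may bear on it.

compound 1 `O=C1/C(=C/c2cccc(Cl)c2)CCCc2ccccc21` — 23800 nM
compound 2 `O=C1/C(=C/c2ccc(Cl)cc2)CCCc2ccccc21` — 33000 nM
compound 3 `O=C1/C(=C/c2cccc(Br)c2)CCCc2ccccc21` — 17100 nM

Three compounds were tested in a functional assay on MOLT-4 cells (Homo sapiens) for inhibition; a lower number here means a stronger inhibitor, a higher number a weaker inhibitor. Compound 1 gives 23800 nM, compound 2 gives 33000 nM and compound 3 gives 17100 nM. Compound 1 and compound 2 have the same atoms joined differently; the difference between their cores is not broken down here, and their two values lie within the usual scatter of each other. From compound 1 to compound 3 the change is bromo in place of chloro on an aromatic carbon. It made a 1.4-fold lower number from compound 1 to compound 3 (0.14 log units; within the scatter).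

Compound 4 `O=C1/C(=C/c2ccc(Br)cc2)CCCc2ccccc21` has not yet been measured in this assay. It differs from compound 2 by bromo in place of chloro on an aromatic carbon. The two changes are the same kind of change, not the same: in compound 3 the bromo sits meta to a large group, in compound 4 para to a large group.

For compound 4 a step of a 1.3-fold lower number from compound 2 to compound 4 (0.12 log units; within the scatter) is expected. That expectation rests on compound 1 and compound 3, where the same kind of change made a 1.4-fold lower number from compound 1 to compound 3 (0.14 log units; within the scatter), a step within the scatter. Compound 4 is therefore estimated at 25000 nM, between 12000 nM and 50000 nM.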

Compound 4, half-maximal inhibitory concentration: 54700 nM
For compound 4 the middle estimate is 2.2-fold (0.34 log units) below the measured one; measured number above the stated range.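

In this assay, bromo in place of chloro, para to a large group, made a 1.7-fold higher number from compound 2 to compound 4 (0.22 log units; within the scatter). Both this step and the earlier one lie within the scatter, and so does the gap between them, so the data give no sign that the change behaves differently on the two cores: the same change on two cores in this assay, a 1.4-fold lower number (0.14 log units; within the scatter) from compound 1 to compound 3 and a 1.7-fold higher number (0.22 log units; within the scatter) from compound 2 to compound 4, 2.3-fold (0.36 log units) apart, within the scatter of two such steps

This supports only a limited statement: on both pairs, the exchange of chloro for bromo left the number within the usual scatter, whether the bromo sat meta or para to a large group. It does not show that bromo is truly better or worse than chloro on either core, and two pairs are too few to make a rule for the series.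

The compounds shown carry only chloro or bromo on this aromatic ring, so how fluoro, methoxy, an amine or a carboxylic acid would read in this assay remains open. Also open, going by these compounds, is whether any such group would produce a step beyond the scatter.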